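The compounds below may be only part of what the source reports. "The series", "measured", "known", "first", "only" and "open" are said of these compounds alone.

Compound 1 `O=C1c2sccc2NS(=O)(=O)N1Cc1ccccc1` gives 374000 nM in an ADME assay on MT4 cells (Homo sapiens) for cytotoxicity, read by MTT assay, with a stated time of 4 days; a lower number here means that less compound is tolerated, a higher number that more compound is tolerated.
Compound 2 `N#Cc1ccccc1CN1c2ccsc2C(=O)N(Cc2ccccc2)S1(=O)=O` gives > 305000 nM in this assay, which is a limit of the assay and not a number.
Compound 3 `N#Cc1cccc(CN2c3ccsc3C(=O)N(Cc3ccccc3)S2(=O)=O)c1` gives > 305000 nM in this assay, again a limit of the assay rather than a number.

Compound 3 therefore stands only at a limit on the numbers shown, and it shares that position with one other compound, as the limit of > 305000 nM in this assay, at which 2 of the 3 values shown sit, records. The step from compound 3 to compound 4 `O=C1c2sccc2N(Cc2ccc([N+](=O)[O-])cc2)S(=O)(=O)N1Cc1ccccc1` changes (4-nitrophenyl in place of 3-cyanophenyl on a saturated chain carbon bound to a sulfonamide nitrogen in a ring).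

The measured step closest in kind is a step that the two limits leave unreadable from compound 2 to compound 3, a change of the aryl group on the same carbon, but both of its ends sit at a limit, so its size cannot be read. The same holds for a step that the limit leaves unreadable from compound 1 to compound 2 and a step that the limit leaves unreadable from compound 1 to compound 3, each of which ends at a limit. Among the compounds with values here, no measured step in this assay thus shows a readable size or direction, and nothing among them points to movement beyond the scatter once the aryl group on that carbon is exchanged.

Compound 4 is accordingly expected to remain at or near the limit, with an estimate of 305000 nM and a range from 150000 nM to 400000 nM. The step of a number no higher from compound 3 to compound 4 (the limit leaves the size open) is expected to be no clear change.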

Compound 4, half-maximal cytotoxic concentration: 268000 nM
For compound 4 the middle estimate is 1.1-fold (0.06 log units) above the measured one; the range from low to high includes it.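

Compound 4 gives 268000 nM in this assay, the first plain number for a compound with an aryl group on the saturated chain carbon bound to a sulfonamide nitrogen in a ring, whereas the earlier steps cannot be read: the limit of > 305000 nM in this assay, at which 2 of the 4 values shown sit.

With 4-nitrophenyl in place of 3-cyanophenyl the result is an at least 1.1-fold lower number from compound 3 to compound 4 (0.05 log units; that floor lies within the scatter), and with 4-nitrophenyl in place of 2-cyanophenyl it is an at least 1.1-fold lower number from compound 2 to compound 4 (0.05 log units; that floor lies within the scatter), so neither step shows a change beyond the scatter, though each gives only a floor for its size. Within the data shown here, compound 1, which carries hydrogen on that nitrogen, gives 374000 nM, and with compound 4 this makes the only two plain numbers in the set.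

On these data alone, how far compound 2 and compound 3 lie past their limits stays open, and with it the true size of both steps. Also open, as far as these compounds go, is whether an amine or a carboxylic acid in place of the 4-nitrophenyl, or a longer chain on that nitrogen, would move the number in this assay beyond the scatter.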